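This account rests on a few compounds, and the source may have more. Where it says the series, first, only, none or still open, it means among the compounds named here.

Working notes on the anilide series. The series shares the core of compound 1, `N#Cc1cc(F)cc(C(=O)Nc2ccccc2F)c1`, in which the anilide carries a fluoro on the aromatic carbon next to the amide linkage. In an in vitro functional assay on HEK293-A cells for antagonist activity at metabotropic glutamate receptor 5 (Rattus norvegicus), read by calcium flux (a lower number here means a stronger inhibitor, a higher number a weaker inhibitor), compound 1 gives only a limit, > 30000 nM, and no number. Compound 2, `N#Cc1cc(F)cc(C(=O)Nc2ccc(F)cc2)c1`, carries its fluoro on a different carbon of the anilide. In this assay compound 2 likewise gives only a limit, > 10000 nM. Where compound 1 stands on the numbers shown is therefore no more than a limit, and the one further value shown is a limit too (the limit of > 10000 nM in this assay, at which 1 of the 2 values shown sits, (the limit of > 30000 nM in this assay, at which 1 of the 2 values shown sits)), so no ranking between compound 1 and compound 2 can be drawn. The next compound, compound 3, `N#Cc1cc(F)cc(C(=O)Nc2ccccc2Cl)c1`, differs from compound 1 by chloro in place of fluoro on an aromatic carbon. Among the compounds with values here, no step between two measured compounds is available to size this change. Compound 3 is expected to sit at 20000 nM, within a range from 3000 nM to 100000 nM. The expected step is an at least 1.5-fold lower number from compound 1 to compound 3 (0.17 log units; that floor lies within the scatter), that is, no shift beyond the scatter, with a fair chance that this assay again reports only a limit.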

Compound 3, half-maximal inhibitory concentration: > 30000 nM
Compound 3 was reported as a limit (the forecaster's own chance of this, stated with the estimate: 65%); middle value at least 1.5-fold (0.17 log units) from the limit.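

No step can be read between compound 1 and compound 3 in this assay, as both sit at the same limit: the limit of > 30000 nM in this assay, at which 2 of the 3 values shown sit. The compounds shown leave open whether chloro in place of fluoro on an aromatic carbon changes inhibition at all, and whether any anilide of this series gives a number rather than a limit.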